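Chain extension at the amide of compound 3

A few compounds are considered here, and "the series" means these few. Any claim that something is new, unique, unknown or untested is made for them only; others in the source may bear on it.

In a functional assay on Caco-2 cells (Homo sapiens), read by MTT assay, with a stated time of 48 h (a higher number here means a weaker inhibitor, a lower number a stronger inhibitor), compound 3 `CCn1c(C(=O)NCCN(C)C)ccc1C(CC)(CC)c1ccc(OCC(O)C(C)(C)C)c(C)c1` gives 1300 nM, within the scatter of compound 1 `CCn1c(C(=O)NCCCN(C)C)ccc1C(CC)(CC)c1ccc(OCC(=O)C(C)(C)C)c(C)c1` at 1400 nM. Within the data shown here, compound 2 `CCOC(=O)CN(C)C(=O)c1ccc(C(CC)(CC)c2ccc(OCC(O)C(C)(C)C)c(C)c2)n1CC` gives 12200 nM, and the one measured step is a 9.4-fold lower number from compound 2 to compound 3 (0.97 log units; beyond the scatter). Compound 4 `CCn1c(C(=O)NCCCN(C)C)ccc1C(CC)(CC)c1ccc(OCC(O)C(C)(C)C)c(C)c1` carries (dimethylamino)methyl in place of dimethylamino on a saturated chain carbon, two bonds along the chain from an amide-type nitrogen. The measured step changed the same amide substituent, but through a much larger exchange, so it sets no size here. Compound 1 at 1400 nM already holds (3-(dimethylamino)propyl)amino on its carbonyl, though it differs from compound 4 elsewhere. No step beyond the scatter is therefore expected in this assay. The expected step is no change at the digits printed from compound 3 to compound 4 (within the scatter). The estimate for compound 4 is 1300 nM, with an expected range of 600 nM to 2800 nM.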

Compound 4, half-maximal inhibitory concentration: 1900 nM
Compound 4: middle estimate off by 1.5-fold (0.16 log units), on the low side; low and high end bracket the measured number.
By their numbers in this assay, from the lowest: compounds 3, 1 and 4 (each within the scatter of the next); then compound 2.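

In this assay, the direct chain extension, (3-(dimethylamino)propyl)amino in place of (2-(dimethylamino)ethyl)amino on the carbonyl, gives a 1.5-fold higher number from compound 3 to compound 4 (0.16 log units; within the scatter). The advantage over ((ethoxycarbonyl)methyl)(methyl)amino also holds with the longer chain, with a 6.4-fold lower number from compound 2 to compound 4 (0.81 log units; beyond the scatter). With this chain fixed, 1-hydroxy-2,2-dimethylpropyl in place of (tert-butyl)carbonyl gives a 1.4-fold higher number from compound 1 to compound 4 (0.13 log units; within the scatter). Still open, from the compounds shown here alone, is whether a longer chain or a piperidine at the chain end would move the number beyond the scatter. No measured evidence bearing on these results is available.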